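Hydrazone aryl variation on the shared triazole thioether core

The source may hold more compounds than are shown below. What is called first, only, known or untested is meant among the compounds shown, and "the series" means these compounds.

Three measured members of the series share the core seen in compound 1 `Fc1ccc(CSc2nnc(-c3ccncc3)n2-c2ccccc2)cc1`, which in a functional assay on HepG2 cells (Homo sapiens) for inhibition, read by MTT assay, with a stated time of 48 h (a lower number here means a stronger inhibitor, a higher number a weaker inhibitor), gives 15600 nM. Compound 2 `O=C(CSc1nnc(-c2ccncc2)n1-c1ccccc1)N/N=C/c1ccc([N+](=O)[O-])cc1` carries a nitro-substituted benzylidene hydrazide and gives 15900 nM. Compound 3 `O=C(CSc1nnc(-c2ccncc2)n1-c1ccccc1)N/N=C/c1ccc(Cl)cc1` gives 11000 nM. Compound 3 holds the lowest of the three numbers, but its gap to compound 1 and to compound 2 is within the scatter, so no order among the three can be claimed. Within the data shown here, the one single-point step so far, a 1.4-fold lower number from compound 2 to compound 3 (0.16 log units; within the scatter), exchanges one substituent on the hydrazone aryl ring and also stays within the scatter.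

Compound 4 `O=C(CSc1nnc(-c2ccncc2)n1-c1ccccc1)N/N=C/c1ccccc1O` differs from compound 3 by 2-hydroxyphenyl in place of 4-chlorophenyl on a carbon with a double bond to nitrogen. Among the measured compounds shown here, the only step that bears on it is the aryl substituent exchange from compound 2 to compound 3, which was small; no measured pair covers a hydroxyl on this ring. On that basis the step of a 1.1-fold higher number from compound 3 to compound 4 (0.04 log units; within the scatter) is expected to stay within the scatter. Compound 4 is therefore estimated at 12000 nM, with a range from 5000 nM to 30000 nM.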

Compound 4, half-maximal inhibitory concentration: 11300 nM
Beside the measured number, compound 4's estimate is 1.1-fold (0.03 log units) above it; low and high end bracket the measured number.
By their numbers in this assay, from the lowest: compounds 3, 4, 1 and 2 (each within the scatter of the next).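

In this assay the step of a 1.0-fold higher number from compound 3 to compound 4 (0.01 log units; within the scatter) and the step of a 1.4-fold lower number from compound 2 to compound 4 (0.15 log units; within the scatter) both stay within the scatter, so 2-hydroxyphenyl cannot be told apart from 4-chlorophenyl or 4-nitrophenyl on this carbon with a double bond to nitrogen. Unlike the earlier exchange of chloro for nitro, these steps bring in a hydroxyl, with a hydrogen-bond donor and acceptor that the leaving groups lack, and the number shows no change beyond the scatter. The exchange alters the substituent and its place on the ring together, so the two contributions cannot be separated, and nothing available explains the flat result.

From the compounds shown here alone, whether an amine or a carboxylic acid on this aryl ring would give a step beyond the scatter remains open. So far, no change at this position has produced a readable difference.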